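The source may report more compounds than this note shows. Statements on the series, on what has been measured and on what is new or still open speak of the compounds shown alone.

Compound 1 `CCO/C(O)=C1\C(COCCn2ccnn2)=NC(C)=C(C(=O)OC)C1c1cccc(Cl)c1Cl`: 0.5 h
Compound 2 `CCO/C(O)=C1\C(COCCN2CC(=O)N(C)C2=O)=NC(C)=C(C(=O)OC)C1c1cccc(Cl)c1Cl`: 0.167 h

For the measured compounds named here, in an ADME assay for pharmacokinetics (a higher number here means that the compound lasts longer, a lower number that the compound disappears faster), compound 2 holds the lower of the two numbers, and the only measured step is a 3.0-fold lower number from compound 1 to compound 2 (0.48 log units; beyond the scatter), a modest change from swapping the ring on the chain. Compound 3 `CCO/C(O)=C1\C(COCCN2CC(=O)N=C2N)=NC(C)=C(C(=O)OC)C1c1cccc(Cl)c1Cl` is made from compound 2 by a group of 7 heavy atoms (3 carbon, 3 nitrogen, 1 oxygen; one five-membered non-aromatic ring with 2 hetero atoms) in place of a group of 8 heavy atoms (4 carbon, 2 nitrogen, 2 oxygen; one five-membered non-aromatic ring with 2 hetero atoms), on a saturated chain carbon, two bonds along the chain from an oxygen on a saturated carbon. Going by the values given here, no measured step covers this exact exchange; the one step known, a ring swap at the same place, moved the half-life only modestly. The step from compound 2 to compound 3 is therefore expected to be small as well, a 1.5-fold higher number from compound 2 to compound 3 (0.18 log units; within the scatter), with the direction uncertain. Compound 3 is estimated at 0.25 h, between 0.08 h and 0.8 h.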

Compound 3, half-life: > 3 h
Compound 3: only a limit was reported (the forecaster's own chance of this, stated with the estimate: 5%); middle value at least 12-fold (1.07 log units) away from the limit.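

In this assay, the group on this saturated chain carbon can matter far more than the first step suggested, with an at least 17-fold higher number from compound 2 to compound 3 (1.25 log units; beyond the scatter) and an at least 6.0-fold higher number from compound 1 to compound 3 (0.77 log units; beyond the scatter). The ring entering in compound 3 therefore outlasts both earlier rings, although all three are five-membered and the exchange is small in heavy atoms. The reading for compound 3 is a limit, not a number: the limit of > 3 h in this assay, at which 1 of the 3 values shown sits.

On these data alone, how far compound 3 truly lies past that limit stays open. So does whether a simple amine or a carboxylic acid at this place would last as long.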